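Adding a methoxy to a compound at the limit

The compounds below may be only part of what the source reports. "The series", "measured", "known", "first", "only" and "open" are said of these compounds alone.

Compounds measured in an ADME assay on BJ cells (Homo sapiens) for cytotoxicity, read by MTT assay, with a stated time of 72 h; a higher number here means a weaker inhibitor, a lower number a stronger inhibitor

compound 1 `COc1ccc(OC)c(CNc2ncnc3c2ncn3C2CCCCO2)c1` gives > 100000 nM
compound 2 `COc1ccccc1CNc1ncnc2c1ncn2C1CCCO1` gives > 100000 nM
compound 3 `COc1cccc(CNc2ncnc3c2ncn3C2CCCO2)c1` gives > 100000 nM

All of these entries are limits and not numbers. So far, the measurements stop at the limit of > 100000 nM in this assay, at which 3 of the 3 values shown sit, and none gives a true half-maximal value.

As far as these compounds go, compound 3 gives > 100000 nM and that is a limit, so its exact place is unknown. Compound 4 `COc1ccc(OC)c(CNc2ncnc3c2ncn3C2CCCO2)c1` is built from compound 3 by placing methoxy in place of hydrogen on an aromatic carbon, ortho to a large group and para to a methoxy group methoxy in place of hydrogen on an aromatic carbon and it has not yet been measured.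

Going by the values given here, the only measured step that bears on this is a step that the two limits leave unreadable from compound 2 to compound 3 so it offers no size to carry over. The closest guide is compound 1, which also carries a second methoxy group on its aromatic ring. Compound 1 gives > 100000 nM and that too is a limit. Among the compounds with values here, no measured compound therefore points to a real change in either direction.

The expected size of the step of a number no higher from compound 3 to compound 4 (the limit leaves the size open) stays within the usual scatter. The estimate for compound 4 is 100000 nM with an expected range from 60000 nM to 200000 nM and a report as a limit is the likeliest outcome.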

Compound 4, half-maximal inhibitory concentration: > 50000 nM
Compound 4 gave a limit, no number (the forecaster's own chance of this, stated with the estimate: 90%); the middle value does not contradict the limit.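

Compound 4 gives > 50000 nM, which is a limit and not a number. Going by these compounds alone, compound 1, compound 2 and compound 3 also give only limits, so no step between compound 4 and any of them can be read. As far as these compounds go, whether methoxy in place of hydrogen, or oxolan-2-yl in place of oxan-2-yl, changes the result in this assay stays open.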